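Working notes on the step to compound 3

The source may report more compounds than this note shows. Statements on the series, on what has been measured and on what is new or still open speak of the compounds shown alone.

Measured in a functional assay on PC-3 cells (Homo sapiens) for inhibition, read by sulforhodamine B assay, with a stated time of 48 h; on this read-out lower numbers stand for stronger inhibition of growth and higher numbers for weaker inhibition of growth:
compound 1 `CCCCCCCCCCCC[C@@H](O)[C@H]1CC[C@H]([C@H](O)CCCCCCCCCCNC(=O)c2ccnn2C)O1`: 18200 nM
compound 2 `CCCCCCCCCCCC[C@@H](O)[C@H]1CC[C@H]([C@H](O)CCCCCCCCCCN(C)C(=O)c2ccnn2C)O1`: 2190 nM

Of the two measured compounds, compound 2 has the lower number, at 2190 nM. Compound 3 `CCCCCCCCCCCC[C@@H](O)[C@H]1CC[C@H]([C@H](O)CCCCCCCCCCNCc2ccnn2C)O1` carries ((1-methyl-1H-pyrazol-5-yl)methyl)amino in place of methyl((1-methyl-1H-pyrazol-5-yl)carbonyl)amino on a saturated chain carbon, ten or more bonds along the chain from an oxygen on a saturated carbon and a saturated ring carbon. Going by the values given here, the one measured step, an 8.3-fold lower number from compound 1 to compound 2 (0.92 log units; beyond the scatter), came from methyl in place of hydrogen on an amide-type nitrogen. Among the compounds with values here, the new change also gives up that methyl, but it removes the carbonyl as well, and no measured step covers that. A smaller step toward a higher number is therefore expected in this assay, and the expected size is a 2.1-fold higher number from compound 2 to compound 3 (0.31 log units; beyond the scatter). For compound 3 the estimate is 4500 nM, with a range of 1100 nM to 18000 nM.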

Compound 3, concentration for 50% growth inhibition: 2290 nM
Compound 3: middle estimate off by 2.0-fold (0.29 log units), on the high side; measured number inside the range.
By their numbers in this assay, from the lowest: compounds 2 and 3 (each within the scatter of the next); then compound 1.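

In this assay, ((1-methyl-1H-pyrazol-5-yl)methyl)amino and methyl((1-methyl-1H-pyrazol-5-yl)carbonyl)amino cannot be told apart at this place, with a 1.0-fold higher number from compound 2 to compound 3 (0.02 log units; within the scatter). The carbonyl is thus not needed to reach this level, and replacing it on the amine nitrogen gives a 7.9-fold lower number from compound 1 to compound 3 (0.90 log units; beyond the scatter), so two different changes to compound 1 end within the scatter of each other. No available measurement bears on the reason for this result.

Still open, from the compounds shown here alone, is whether a methyl on the amine nitrogen of compound 3, giving a tertiary amine, would shift the number. Going by these compounds, it is also open whether a sulfonamide in place of the amide of compound 2 would hold it.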